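Swapping Diethylamino for Methoxy on a Phenol Hydrazone

The compounds below may be only part of what the source reports. "The series", "measured", "known", "first", "only" and "open" are said of these compounds alone.

Compound 1 `O=C(N/N=C/c1ccccn1)c1cccc(S(=O)(=O)N2CCOCC2)c1`: in a functional assay on MCF7 cells (Homo sapiens) for antiproliferative activity, read by MTT assay, with a stated time of 72 h (a higher number here means a weaker inhibitor, a lower number a stronger inhibitor), compound 1 gives > 100000 nM
Compound 2 `CCN(CC)c1ccc(/C=N/NC(=O)c2cccc(S(=O)(=O)N3CCOCC3)c2)c(O)c1`: in this assay compound 2 gives 3520 nM

The value for compound 1 is a limit of the assay and not a number, (the limit of > 100000 nM in this assay, at which 1 of the 2 values shown sits). Among the measured compounds shown here, compound 2 is therefore the only compound with a measured number, and it stands alone. Compound 3 `COc1ccc(/C=N/NC(=O)c2cccc(S(=O)(=O)N3CCOCC3)c2)c(O)c1` arises from compound 2 by methoxy in place of diethylamino on an aromatic carbon. For the measured compounds named here, no measured pair shows this change, so the expectation rests on compound 2 alone. The step from compound 2 to compound 3 is expected to be a weakening, a 2.8-fold higher number from compound 2 to compound 3 (0.45 log units; beyond the scatter), somewhat beyond the scatter. Compound 3 is expected to give 10000 nM in this assay, within 3000 nM to 50000 nM.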

Compound 3, half-maximal inhibitory concentration: 5140 nM
Compound 3: middle estimate off by 1.9-fold (0.29 log units), on the high side; the range from low to high includes it.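

Compound 2 and compound 3 cannot be told apart in this assay, with a 1.5-fold higher number from compound 2 to compound 3 (0.16 log units; within the scatter), so this position holds either diethylamino or methoxy with no difference beyond the scatter. Far more separates the compounds at the other end: 2-hydroxy-4-methoxyphenyl in place of pyridin-2-yl gives an at least 19-fold lower number from compound 1 to compound 3 (1.28 log units; beyond the scatter). The value of compound 1 is a limit of the assay and not a number: the limit of > 100000 nM in this assay, at which 1 of the 3 values shown sits.

As far as these compounds go, whether a carboxylic acid or a longer chain such as butoxy would also be held at this position stays open. So does the share of the hydroxy group in the large step, since that step swaps the whole ring.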